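Methyl in Place of Phenyl on a Shared Core

The source may hold more compounds than are shown below. What is called first, only, known or untested is meant among the compounds shown, and "the series" means these compounds.

Compound 1 `CCCCCCCCNc1n[n+]([O-])c2ccccc2[n+]1[O-]`: 18200 nM
Compound 2 `C=CCNc1n[n+]([O-])c2ccccc2[n+]1[O-]`: > 56000 nM
Compound 3 `[O-][n+]1nc(NCc2ccccc2)[n+]([O-])c2ccccc21`: 10700 nM

Three compounds share one core and differ only in the group on a saturated chain carbon bound to a nitrogen on an aromatic ring. In a functional assay on PC-3 cells (Homo sapiens) for cytotoxicity, read by MTT assay, with a stated time of 48 h (a higher number here means a weaker inhibitor, a lower number a stronger inhibitor), compound 3 gives 10700 nM, the lowest of the two numbers measured; its nearest neighbour is compound 1, and the gap a 1.7-fold lower number from compound 1 to compound 3 (0.23 log units; within the scatter) lies within the scatter. For compound 2 the assay reports only a limit, (the limit of > 56000 nM in this assay, at which 1 of the 3 values shown sits), and not a number.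

Compound 4 `CCNc1n[n+]([O-])c2ccccc2[n+]1[O-]` is not yet measured. Its change from compound 3 is methyl in place of phenyl on a saturated chain carbon bound to a nitrogen on an aromatic ring.

Two measured steps speak to this change. The step of an at least 5.2-fold lower number from compound 2 to compound 3 (0.71 log units; beyond the scatter) shows that a phenyl group at this place gives a lower number than a vinyl group. The step of a 1.7-fold lower number from compound 1 to compound 3 (0.23 log units; within the scatter) shows that a phenyl and a heptyl give about the same number. Replacing phenyl with methyl leaves a small group at this place, like the vinyl of compound 2, so a higher number is expected for compound 4, with a fair chance that this assay again reports only a limit.

The estimated step is a 3.7-fold higher number from compound 3 to compound 4 (0.57 log units; beyond the scatter). For compound 4 the expected value in this assay is 40000 nM, within a range of 15000 nM to 110000 nM.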

Compound 4, half-maximal inhibitory concentration: 13300 nM
Beside the measured number, compound 4's estimate is 3.0-fold (0.48 log units) above it; measured number outside the range, below it.
By their numbers in this assay, from the lowest: compounds 3, 4 and 1 (each within the scatter of the next). At a limit, above all of these: compound 2.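

Shortening the group on the saturated chain carbon from phenyl to methyl leaves the number in the same place in this assay, with a 1.2-fold higher number from compound 3 to compound 4 (0.09 log units; within the scatter) as the step, so a six-membered aromatic ring and a single carbon cannot be told apart here. The longer chain reads the same way, since a 1.4-fold lower number from compound 1 to compound 4 (0.14 log units; within the scatter) also stays within the scatter, and compound 1, compound 3 and compound 4 therefore form one group despite the wide range of sizes at this place. A small group alone thus does not bring a high number, and compound 4 now goes against that idea, as the step for methyl in place of vinyl shows with an at least 4.2-fold lower number from compound 2 to compound 4 (0.62 log units; beyond the scatter) as its size, so compound 2 stands apart from the other three.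

For compound 2 the assay gives a limit and not a number: the limit of > 56000 nM in this assay, at which 1 of the 4 values shown sits.
From the compounds shown here alone, how far compound 2 lies from the others therefore stays open, and so does whether a charged or ring-bearing end on the chain, such as an amine or a carboxylic acid, would keep the number in the range of compound 1, compound 3 and compound 4.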